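This account rests on a few compounds, and the source may have more. Where it says the series, first, only, none or still open, it means among the compounds named here.

Compound 1 `Cc1ccsc1-c1cncc(Cl)c1N1CCC2(CCNC2=O)CC1` gives 910 nM
Compound 2 `Cc1ccc(-c2cncc(Cl)c2N2CCC3(CCNC3=O)CC2)s1` gives 650 nM
Compound 3 `Cc1cc(-c2cncc(Cl)c2N2CCC3(CCNC3=O)CC2)sc1C=O` gives 2530 nM

Compound 2 stands in the lower pair of values in a functional assay on MV4-11 cells (Homo sapiens) for inhibition, read by resazurin assay, with a stated time of 72 h (on this read-out higher numbers stand for weaker inhibition of growth and lower numbers for stronger inhibition of growth), and the gap within that pair is a 1.4-fold lower number from compound 1 to compound 2 (0.15 log units; within the scatter), while the gap to the remaining compound is a 3.9-fold higher number from compound 2 to compound 3 (0.59 log units; beyond the scatter). Compound 4 `O=C1NCCC12CCN(c1c(Cl)cncc1-c1ccc(CN3CCCCC3)s1)CC2` differs from compound 2 by piperidin-1-yl in place of hydrogen on a saturated chain carbon bound to an aromatic carbon, so that methyl becomes (piperidin-1-yl)methyl. Going by the values given here, the nearest measured evidence is a 3.9-fold higher number from compound 2 to compound 3 (0.59 log units; beyond the scatter) and a 2.8-fold higher number from compound 1 to compound 3 (0.44 log units; beyond the scatter), both changes to the same group, but no measured compound carries piperidin-1-yl. Going by these compounds, no step beyond the scatter is therefore expected in this assay, and the direction stays open. The expected change is a 1.3-fold lower number from compound 2 to compound 4 (0.11 log units; within the scatter). For compound 4 the estimated value is 500 nM, with an expected range from 130 nM to 1900 nM.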

Compound 4, concentration for 50% growth inhibition: 4010 nM
Compound 4: middle estimate off by 8.0-fold (0.90 log units), on the low side, outside the stated range (above it).
By their numbers in this assay, from the lowest: compounds 2 and 1 (each within the scatter of the next); then compounds 3 and 4 (each within the scatter of the next).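

In this assay, piperidin-1-yl in place of hydrogen on the saturated chain carbon bound to an aromatic carbon gives a 6.2-fold higher number from compound 2 to compound 4 (0.79 log units; beyond the scatter). Going by these compounds alone, the earlier steps only moved the methyl or added a formyl group, so this is the first sign that the methyl of compound 2 does not accept a six-membered non-aromatic ring without a loss of growth inhibition. No available evidence accounts for this loss. Going by these compounds, it remains open whether the ring itself matters or any substituent at this carbon would do the same. A morpholin-4-yl group, a primary amine or a carboxylic acid at the same place could read differently.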